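The source may report more compounds than this note shows. Statements on the series, on what has been measured and on what is new or still open speak of the compounds shown alone.

In an assay on HeLa cells for inhibition of Indoleamine 2,3-dioxygenase 1 (Homo sapiens), with a stated time of 20 h (a lower number here means a stronger inhibitor, a higher number a weaker inhibitor), compound 3 `Cc1ccccc1NC(=O)Nc1cc(-c2cccc(C(=O)O)c2)ccc1Oc1ccccc1C(C)(C)C` gives 1000 nM, the lowest of the three numbers seen so far. Compound 1 `CC(C)(C)c1ccccc1Oc1ccc(-c2cccc(C(=O)O)c2)cc1NC(=O)Nc1ccc(OC(F)F)cc1` gives 2600 nM and compound 2 `CC(C)(C)c1ccccc1Oc1ccc(-c2cccc(C(=O)O)c2)cc1NC(=O)Nc1ccc(Br)cc1` gives 2900 nM; a 1.1-fold higher number from compound 1 to compound 2 (0.05 log units; within the scatter). The two steps that reach compound 3 are a 2.6-fold lower number from compound 1 to compound 3 (0.41 log units; beyond the scatter) and a 2.9-fold lower number from compound 2 to compound 3 (0.46 log units; beyond the scatter). Compound 4 `CC(C)(C)c1ccccc1Oc1ccc(-c2cccc(C(=O)O)c2)cc1NC(=O)Nc1ccccc1` differs from compound 3 by hydrogen in place of methyl on an aromatic carbon. Among the measured compounds shown here, no measured step removes that methyl on its own; the two steps that reach compound 3 exchange a whole substituted phenyl, and so they only show that 2-methylphenyl gives a lower number than 4-(difluoromethoxy)phenyl or 4-bromophenyl. Removing the methyl takes the ring of compound 4 part of the way back towards those two, so a modest rise in the number is expected rather than a fall, though a value within the scatter of compound 3 cannot be ruled out. The expected step is a 1.8-fold higher number from compound 3 to compound 4 (0.26 log units; within the scatter). Compound 4 is therefore expected to give 1800 nM, with a range from 800 nM to 4000 nM.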

Compound 4, half-maximal inhibitory concentration: 1500 nM
The estimate for compound 4 lay 1.2-fold (0.08 log units) above the measured number; the range from low to high includes it.
By their numbers in this assay, from the lowest: compounds 3, 4, 1 and 2 (each within the scatter of the next, the first and the last beyond it).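

Removing the methyl, which sits ortho to a large group, gives a step on its own in this assay (a 1.5-fold higher number from compound 3 to compound 4 (0.18 log units; within the scatter)), so this single methyl is not shown to matter, although exchanging the whole substituted phenyl separated compound 3 from compound 1 and compound 2. The plain phenyl ring is not separated from the bromo or difluoromethoxy rings either (a 1.9-fold lower number from compound 2 to compound 4 (0.29 log units; within the scatter); a 1.7-fold lower number from compound 1 to compound 4 (0.24 log units; within the scatter)), so neither of those groups is shown to matter alone. Compound 4 thus lies within the scatter of all three other compounds, and no measurement at hand gives a reason for these numbers.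

On these data alone, it remains open whether ethyl, methoxy or chloro in place of that methyl would move the number beyond the scatter of compound 4. An amine or a hydroxyl on the same ring is also untested among the compounds shown.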